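The source may hold more compounds than are shown below. What is called first, only, known or untested is meant among the compounds shown, and "the series" means these compounds.

Among the measured compounds shown here, compound 1 `Cc1cc(Nc2cc(-c3ccccc3)[nH]n2)n2nc(SCc3ccc(F)cc3)nc2n1` gives 3270 nM in a functional assay on MGC-803 cells (Homo sapiens) for inhibition, read by MTT assay, with a stated time of 72 h (a lower number here means a stronger inhibitor, a higher number a weaker inhibitor), and with that it stands lowest of the two numbers measured, though its only neighbour, compound 2 `Cc1cc(Nc2cc(-c3ccccc3)[nH]n2)n2nc(SCc3ccc(Cl)cc3)nc2n1` with 3950 nM in this assay, sits within the scatter of it. For the measured compounds named here, the one step measured at this position, a 1.2-fold higher number from compound 1 to compound 2 (0.08 log units; within the scatter), is therefore no change beyond the scatter. Compound 3 `Cc1cc(Nc2cc(-c3ccccc3)[nH]n2)n2nc(SCc3ccc(C(F)(F)F)cc3)nc2n1` differs from compound 1 in the same place: trifluoromethyl in place of fluoro on an aromatic carbon. Going by the values given here, only the step from compound 1 to compound 2 bears on it, and that step was small, so a change at this aromatic carbon has so far moved this assay little. Compound 3 is therefore expected to give a number close to that of compound 1, and the expected step of a 1.2-fold higher number from compound 1 to compound 3 (0.09 log units; within the scatter) is judged to lie within the scatter. The estimate for compound 3 in this assay is 4000 nM, with a range from 1800 nM to 9000 nM.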

Compound 3, half-maximal inhibitory concentration: 3520 nM
Beside the measured number, compound 3's estimate is 1.1-fold (0.06 log units) above it; the range from low to high includes it.
By their numbers in this assay, from the lowest: compounds 1, 3 and 2 (each within the scatter of the next).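

Trifluoromethyl brings 4 heavy atoms to this aromatic carbon in place of the 1 of fluoro, yet this assay shows a 1.1-fold higher number from compound 1 to compound 3 (0.03 log units; within the scatter), and against the chloro group it shows a 1.1-fold lower number from compound 2 to compound 3 (0.05 log units; within the scatter). The earlier pair compared only two single halogens, whereas this result extends the flat picture to a group of several atoms, so fluoro, chloro and trifluoromethyl at this place on the ring cannot be told apart in this read-out. Nothing available explains why the number holds so steady across these three groups.

Going by these compounds, all three groups contain halogen, so it remains open whether an amine, a carboxylic acid or a longer chain at this carbon would move the number beyond the scatter. On these data alone, it is also open whether plain hydrogen there would give a similar value.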